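The source may report more compounds than this note shows. Statements on the series, on what has been measured and on what is new or still open speak of the compounds shown alone.

Three compounds share one core and differ only in the ring carried on the oxygen. Compound 1 `COc1cc(Oc2ccc(NC(=O)Nc3cccc(C(F)(F)F)c3)cc2)ncn1` gives 4000 nM in an assay on isolated protein for inhibition of serine/threonine-protein kinase TNNI3K (Homo sapiens); a lower number here means a stronger inhibitor, a higher number a weaker inhibitor. Compound 2 `CNc1nccc(Oc2ccc(NC(=O)Nc3cccc(C(F)(F)F)c3)cc2)n1` gives 50 nM in this assay, and compound 3 `CC(C)Nc1cc(Oc2ccc(NC(=O)Nc3cccc(C(F)(F)F)c3)cc2)ncn1` gives 40 nM in this assay. Compound 3 and compound 2 cannot be told apart, since a 1.3-fold lower number from compound 2 to compound 3 (0.10 log units; within the scatter), and both sit far from compound 1. Compound 4 `O=C(Nc1ccc(Oc2ccncc2)cc1)Nc1cccc(C(F)(F)F)c1` is compound 3 with pyridin-4-yl in place of 6-(isopropylamino)pyrimidin-4-yl on an oxygen on an aromatic ring. The amino-bearing rings mattered: a 100-fold lower number from compound 1 to compound 3 (2.00 log units; beyond the scatter) and an 80-fold lower number from compound 1 to compound 2 (1.90 log units; beyond the scatter). Because a 100-fold lower number from compound 1 to compound 3 (2.00 log units; beyond the scatter) when the amino group gave way to methoxy, dropping the amino group altogether in compound 4 is expected to raise the number by a large step, a 75-fold higher number from compound 3 to compound 4 (1.88 log units; beyond the scatter). Compound 4 is therefore estimated at 3000 nM, within 800 nM to 12000 nM.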

Compound 4, half-maximal inhibitory concentration: 50 nM
For compound 4 the middle estimate is 60-fold (1.78 log units) above the measured one; the whole stated range lies above it.
By their numbers in this assay, from the lowest: compounds 3, 2 and 4 (each within the scatter of the next); then compound 1.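

Neither amino-bearing ring is needed at this place on the oxygen: pyridin-4-yl, with no hydrogen-bond donor and fewer heavy atoms, gives a 1.3-fold higher number from compound 3 to compound 4 (0.10 log units; within the scatter) and no change at the digits printed from compound 2 to compound 4 (within the scatter). The low potency of compound 1 therefore does not come simply from lacking an amino group, as pyridin-4-yl also lacks one and still gives an 80-fold lower number from compound 1 to compound 4 (1.90 log units; beyond the scatter). Nothing measured here explains this. Compound 1 differs from compound 4 in both its methoxy group and its second ring nitrogen, so either could account for the gap. A pyridin-4-yl ring carrying a methoxy group would help separate the two.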